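Removing the methylpiperazine: expected solubility of compound 4

This account rests on a few compounds, and the source may have more. Where it says the series, first, only, none or still open, it means among the compounds named here.

Three compounds of the series have been run in a physicochemical assay for solubility, at pH 7.4; a higher number here means a more soluble compound, a lower number a less soluble compound. Compound 1 `CN1CCN(c2ccccc2C(=O)/C=C/c2ccc(/C=C/C(=O)NO)cc2)CC1` gives 210000 nM. Compound 2 `CN1CCN(c2cccc(C(=O)/C=C/c3cccc(/C=C/C(=O)NO)n3)c2)CC1` gives 380000 nM. Compound 3 `O=C(/C=C/c1ccc(/C=C/C(=O)c2ccccc2)cc1)NO` gives 3000 nM. The numbers for compound 1 and compound 2 lie within the scatter of each other, while compound 3 sits well apart from both. The difference between the cores of compound 1 and compound 2 is not broken down here.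

One structural change recurs twice among these compounds. From compound 1 to compound 3 it is hydrogen in place of 4-methylpiperazin-1-yl on an aromatic carbon and it gave a 70-fold lower number from compound 1 to compound 3 (1.85 log units; beyond the scatter). Compound 4 `O=C(/C=C/c1cccc(/C=C/C(=O)c2ccccc2)n1)NO` has not yet been measured; it differs from compound 2 by hydrogen in place of 4-methylpiperazin-1-yl on an aromatic carbon. The two changes are the same kind of change, not the same: in compound 1 the leaving group sits ortho to a large group, in compound 2 it sits meta to a large group, and the two cores themselves differ. Among the compounds with values here, no second measured precedent exists to show how far the step transfers.

Given that a 70-fold lower number from compound 1 to compound 3 (1.85 log units; beyond the scatter) is the only measured precedent, the expected step in this assay is a 63-fold lower number from compound 2 to compound 4 (1.80 log units; beyond the scatter). The range is kept broad to allow for the change of core and of place. Compound 4 is estimated at 6000 nM in this assay, with a likely range from 1500 nM to 25000 nM.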

Compound 4, solubility: 16000 nM
Compound 4: middle estimate off by 2.7-fold (0.43 log units), on the low side; the measured number falls inside the stated range.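

In this assay, hydrogen in place of 4-methylpiperazin-1-yl on an aromatic carbon now goes with a 70-fold lower number from compound 1 to compound 3 (1.85 log units; beyond the scatter) and with a 24-fold lower number from compound 2 to compound 4 (1.38 log units; beyond the scatter) on the other core, so the direction of the step holds on both cores shown and both steps are large. Two pairs remain a small base: the cores differ and the place of the group differs too, so these pairs cannot separate an influence of the core from an influence of place, and they give no rule for the size of the step on a further core. Nothing at hand bears on the reason for either step.

Only 4-methylpiperazin-1-yl is set against hydrogen in the compounds shown, so it stays open whether a dimethylamino group, a morpholine ring or a carboxylic acid at the same place on the core of compound 4 would hold the number of compound 2 or stay close to that of compound 4. Also open, as far as these compounds go, is how the step reads with 4-methylpiperazin-1-yl at one and the same place on both cores, the pairing that would separate core from place.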